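The compounds below may be only part of what the source reports. "The series", "measured", "known", "first", "only" and "open" are said of these compounds alone.

Measured so far in a physicochemical assay for solubility, read by HPLC, with a stated time of 30 min; on this read-out higher numbers stand for higher solubility and lower numbers for lower solubility:
- compound 1, `O=C(Nc1nc(-c2cccc(F)c2)cs1)c1ccc([N+](=O)[O-])o1`: 14.8 ug/mL
- compound 2, `CC(C)Oc1cccc(-c2csc(NC(=O)c3ccc([N+](=O)[O-])o3)n2)c1`: 0.27 ug/mL

Among the compounds with values here, compound 2 stands at the lowest of the two numbers; the only measured step reaches it, a 55-fold lower number from compound 1 to compound 2 (1.74 log units; beyond the scatter). The next compound, compound 3, `O=C(Nc1nc(-c2cccc(NS(=O)(=O)Cc3ccccc3)c2)cs1)c1ccc([N+](=O)[O-])o1`, is not yet measured. Its change from compound 2 is (benzylsulfonyl)amino in place of isopropoxy on an aromatic carbon. Within the data shown here, the one measured step bears on it only in that the same aromatic carbon is varied; it went from fluoro to isopropoxy and was large, whereas here isopropoxy is itself replaced by a group that brings one hydrogen-bond donor and two acceptors together with a further aromatic ring. Among the measured compounds shown here, no measured pair carries a (benzylsulfonyl)amino group, so the direction is uncertain. The expected step is a 3.0-fold higher number from compound 2 to compound 3 (0.47 log units; beyond the scatter), small, not clearly beyond the scatter. Compound 3 is therefore estimated at 0.8 ug/mL, within 0.1 ug/mL to 6 ug/mL.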

Compound 3, solubility: 0.48 ug/mL
The estimate for compound 3 lay 1.7-fold (0.22 log units) above the measured number, and the stated range covers the measured number.
By their numbers in this assay, from the lowest: compounds 2 and 3 (each within the scatter of the next); then compound 1.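

Notes on this aromatic carbon in this assay: replacing fluoro with (benzylsulfonyl)amino gives a 31-fold lower number from compound 1 to compound 3 (1.49 log units; beyond the scatter) and is the second large step in the same direction, alongside a 55-fold lower number from compound 1 to compound 2 (1.74 log units; beyond the scatter). Exchanging isopropoxy for (benzylsulfonyl)amino gives a 1.8-fold higher number from compound 2 to compound 3 (0.25 log units; within the scatter) and so does not separate these two groups on this read-out, even though the entering group adds an aromatic ring and a hydrogen-bond donor. Among the three compounds, the large gap therefore lies between fluoro and both larger groups, with no compound going against it.

As far as these compounds go, whether methoxy, an amine or a carboxylic acid on this carbon would fall with compound 1 or with compounds 2 and 3 remains open. Nothing available explains the gap from fluoro to the two larger groups.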